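Morpholin-4-yl in place of (1-phenylethyl)amino on the carbonyl carbon

The source may hold more compounds than are shown below. What is called first, only, known or untested is meant among the compounds shown, and "the series" means these compounds.

compound 1 `CCCCCC[C@@H](O)C/C=C\CCCCCCCC(=O)N[C@@H](C)c1ccccc1`: 11.7 ug/mL
compound 2 `CCCCCCCCCCCCCCCCCC(=O)N1CCOCC1`: 41.1 ug/mL
compound 3 `CCCCCCCC/C=C\CCCCCCCC(=O)N1CCCC1`: 13 ug/mL

In a functional assay on PC-3 cells (Homo sapiens) for antiproliferative activity, read by sulforhodamine B assay, with a stated time of 48 h (on this read-out lower numbers stand for stronger inhibition of growth and higher numbers for weaker inhibition of growth), compound 1 lies within the scatter of compound 3, and beyond the scatter below compound 2. Compound 4 (`CCCCCC[C@@H](O)C/C=C\CCCCCCCC(=O)N1CCOCC1`) is still unmeasured. Relative to compound 1 it carries morpholin-4-yl in place of (1-phenylethyl)amino on a carbonyl carbon. Going by the values given here, no measured pair isolates this change. Among the compounds with values here, compound 2 also carries morpholin-4-yl, on a different chain, and gives 41.1 ug/mL in this assay as the only guide. A modest rise at the edge of the scatter is therefore expected, the estimated step being a 1.9-fold higher number from compound 1 to compound 4 (0.27 log units; within the scatter) towards weaker inhibition of growth. Compound 4 is expected at 22 ug/mL (estimated range 10 ug/mL to 45 ug/mL).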

Compound 4, concentration for 50% growth inhibition: 38.5 ug/mL
The estimate for compound 4 lay 1.8-fold (0.24 log units) below the measured number, within the range that was stated.
By their numbers in this assay, from the lowest: compounds 1 and 3 (each within the scatter of the next); then compounds 4 and 2 (each within the scatter of the next).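

In this assay, morpholin-4-yl in place of (1-phenylethyl)amino on a carbonyl carbon gives a 3.3-fold higher number from compound 1 to compound 4 (0.52 log units; beyond the scatter), towards weaker inhibition of growth. Going by these compounds alone, this is the first step that isolates a change at this place, and it shows that the group on the carbonyl carbon matters with the rest of compound 1 held constant. Nothing measured here accounts for the step. Still open, going by these compounds, is which departing feature counts: the aromatic ring, the amide hydrogen or the defined stereocentre. Benzylamino or piperidin-1-yl on the same carbonyl carbon would help separate these.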